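Benzamido for phenoxy: next step from compound 3

This account rests on a few compounds, and the source may have more. Where it says the series, first, only, none or still open, it means among the compounds named here.

Of the compounds shown here, three measured so far share one core. Compound 1 `O=C(O)/C=C/c1ccc2noc(-c3ccc(OC(F)(F)F)cc3)c2c1` carries trifluoromethoxy; in an assay for inhibition of inositol hexakisphosphate kinase 3 (Homo sapiens), read by colorimetric assay, coupled enzyme assay and malachite green, with a stated time of 120 min, in the presence of a further agent that is not named here (a lower number here means a stronger inhibitor, a higher number a weaker inhibitor), compound 1 gives 8370 nM. Compound 2 `O=C(O)/C=C/c1ccc2noc(-c3ccc(Oc4ccccc4)cc3)c2c1` carries phenoxy instead and gives 760 nM; the step of an 11-fold lower number from compound 1 to compound 2 (1.04 log units; beyond the scatter) is the one large move in the set. Compound 3 `O=C(O)c1ccc2noc(-c3ccc(Oc4ccccc4)cc3)c2c1`, with carboxy in place of 2-carboxyethenyl, gives 550 nM; the step of a 1.4-fold lower number from compound 2 to compound 3 (0.14 log units; within the scatter) stays inside the scatter. Compound 3 thus holds the lowest number of the three, but it cannot be separated from compound 2 and stands apart only from compound 1.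

Compound 4 `O=C(O)c1ccc2noc(-c3ccc(NC(=O)c4ccccc4)cc3)c2c1` changes the group on an aromatic carbon of a six-membered aromatic ring of carbon only, the site altered in the first step: benzamido in place of phenoxy on an aromatic carbon. Among the compounds with values here, no measured step covers exchange of an oxygen link for an amide link with the phenyl kept. The step from compound 1 to compound 2 shows the site tolerates a large group; the step from compound 2 to compound 3 does not touch it. With the aromatic ring retained and only the link changed, no move beyond the scatter is expected, the estimated step being a 1.1-fold higher number from compound 3 to compound 4 (0.04 log units; within the scatter). Compound 4 is expected to give about 600 nM, within 200 nM to 2000 nM.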

Compound 4, half-maximal inhibitory concentration: 200 nM
Compound 4: the middle estimate sits 3.0-fold (0.48 log units) above what was measured; low and high end bracket the measured number.
By their numbers in this assay, from the lowest: compound 4; then compounds 3 and 2 (each within the scatter of the next); then compound 1.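

In this assay, within the data shown here, exchanging the oxygen link for an amide link with the phenyl kept gives a 2.8-fold lower number from compound 3 to compound 4 (0.44 log units; beyond the scatter) and so shows that this position responds to the link itself, which the earlier compounds could not show. The step of an 11-fold lower number from compound 1 to compound 2 (1.04 log units; beyond the scatter) changed the whole group on the oxygen, whereas here a terminal six-membered aromatic ring of carbon only stands on both sides of the change, and benzamido differs from phenoxy by bringing a hydrogen-bond donor and a double bond outside aromatic rings. No measurement shown here accounts for the step or assigns it to either of these differences.

Still open, going by these compounds, is which part of the amide link carries the step: an N-methyl benzamido group, a reversed amide or a urea link in the same place would separate the amide hydrogen from the carbonyl. Also open, on these data alone, is whether the step holds with 2-carboxyethenyl in place of carboxy on the shared core, and whether a tetrazole can stand in for the carboxylic acid.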